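The source may hold more compounds than are shown below. What is called first, only, known or untested is meant among the compounds shown, and "the series" means these compounds.

Compound 1 `OCC#CCSc1cnc2ccccc2c1SCC#CCBr`: 0.6 ug/mL
Compound 2 `OCC#CCSc1cnc2ccccc2c1[Se]CC#CCO`: 1.4 ug/mL
Compound 3 `C[Se]c1c(SCC#CCO)cnc2ccccc12`: 2.1 ug/mL

In a functional assay on CCRF-CEM cells (Homo sapiens) for cytotoxicity, read by sulforhodamine B assay, with a stated time of 72 h (a lower number here means a stronger inhibitor, a higher number a weaker inhibitor), compound 3 gives the highest of the three numbers, though its distance from compound 2 is a 1.5-fold higher number from compound 2 to compound 3 (0.18 log units; within the scatter) and lies within the scatter; only its distance from compound 1, a 3.5-fold higher number from compound 1 to compound 3 (0.54 log units; beyond the scatter), is beyond it. Compound 4 `CSc1c(SCC#CCO)cnc2ccccc12` differs from compound 3 by a group of 2 heavy atoms (1 carbon, 1 sulfur; no ring) in place of a group of 2 heavy atoms (1 carbon, 1 selenium; no ring), on an aromatic carbon. For the measured compounds named here, no measured step isolates this exchange: a 2.3-fold higher number from compound 1 to compound 2 (0.37 log units; beyond the scatter) replaces the whole group at that position together with its chain, and a 1.5-fold higher number from compound 2 to compound 3 (0.18 log units; within the scatter) changes the chain alone. With nothing in the measured steps bearing directly on this change, no shift beyond the scatter is expected, and compound 4 is estimated at 2.1 ug/mL (range 1 ug/mL to 4.5 ug/mL), a step of no change at the digits printed from compound 3 to compound 4 (within the scatter).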

Compound 4, concentration for 50% inhibition: 13.9 ug/mL
Beside the measured number, compound 4's estimate is 6.6-fold (0.82 log units) below it; the whole stated range lies below it.
By their numbers in this assay, from the lowest: compound 1; then compounds 2 and 3 (each within the scatter of the next); then compound 4.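

In this assay, for the compounds shown here, methylsulfanyl in place of the selenium-bearing group of the same size on this aromatic carbon, opposite the ring nitrogen, is the first change seen with the selenium exchanged alone, and it is beyond the scatter (a 6.6-fold higher number from compound 3 to compound 4 (0.82 log units; beyond the scatter)). Compound 4 also stands apart from the compounds with longer chains (a 9.9-fold higher number from compound 2 to compound 4 (1.00 log units; beyond the scatter); a 23-fold higher number from compound 1 to compound 4 (1.36 log units; beyond the scatter)), so its number is the highest of the four. No measurement shown accounts for this difference.

As far as these compounds go, whether the same exchange would count as much with the longer chain of compound 2 remains open. So does where an amine or a methoxy group at this position would fall.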